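Metabolic stability notes: azetidine amide against open-chain amide

A few compounds are considered here, and "the series" means these few. Any claim that something is new, unique, unknown or untested is made for them only; others in the source may bear on it.

Measured compounds:
compound 1 `CN(C)C(=O)CCNC(=O)c1cc(-c2ccc(F)cc2)no1`, 87%
compound 2 `CN(C)C(=O)CCNC(=O)c1cc(-c2ccccc2F)no1`, a limit of the assay, > 100%
compound 3 `CC(=O)N1CC(CNC(=O)c2cc(-c3ccccc3)no2)C1`, 50%

In an ADME assay on microsomes from liver (Homo sapiens) for metabolic stability, with a stated time of 0.5 h, tested at 0.5 mg/mL (on this read-out lower numbers stand for a less stable compound and higher numbers for a more stable compound), compound 3 holds the lowest of the two numbers. Its nearest neighbour is compound 1, which sits higher by an amount beyond the scatter. Compound 2 is reported only at a limit, (the limit of > 100% in this assay, at which 1 of the 3 values shown sits).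

Compound 4 `CN(C)C(=O)CCNC(=O)c1cc(-c2ccccc2)no1` is not yet measured. It differs from compound 3 by (dimethylcarbamoyl)methyl in place of 1-acetylazetidin-3-yl on a saturated chain carbon bound to an amide-type nitrogen. Going by the values given here, the only measured step, a number at least 13 percentage points higher from compound 1 to compound 2 (beyond the scatter), concerns the fluorine on the aryl group and does not touch the part that changes here, so it gives no direct guide. What does bear on it is that compound 1 and compound 2, both carrying the (dimethylcarbamoyl)methyl chain that enters in compound 4, sit well above compound 3 in this assay, with compound 2 at a limit.

On that basis the step from compound 3 to compound 4 is expected to be a number 30 percentage points higher from compound 3 to compound 4 (beyond the scatter), upward and beyond the scatter. Compound 4 is therefore estimated at 80%, within 60% to 100%, in this assay.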

Compound 4, percent of the compound remaining: 81%
Compound 4: the middle estimate sits 1 percentage points below what was measured; the range from low to high includes it.
By their numbers in this assay, from the lowest: compound 3; then compounds 4 and 1 (each within the scatter of the next). At a limit, above all of these: compound 2.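

In this assay, going by these compounds alone, the exchange of 1-acetylazetidin-3-yl for (dimethylcarbamoyl)methyl on a saturated chain carbon bound to an amide-type nitrogen now has a direct reading with the rest of the structure unchanged: a number 31 percentage points higher from compound 3 to compound 4 (beyond the scatter), so this place carries a large change, which the earlier compounds showed only across differing aryl groups. Hydrogen in place of fluoro on an aromatic carbon gives two different readings, since a number 6 percentage points lower from compound 1 to compound 4 (within the scatter) does not separate the 4-fluorophenyl compound from the compound without fluoro, whereas a number at least 19 percentage points lower from compound 2 to compound 4 (beyond the scatter) separates the 2-fluorophenyl compound from it, so the fluoro effect depends on where the fluoro sits in these compounds. The second of these readings is a bound and not a size, as compound 2 is reported only at a limit of the assay: the limit of > 100% in this assay, at which 1 of the 4 values shown sits.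

Still open, on these data alone, is whether the step at the chain holds with a 2-fluorophenyl or 4-fluorophenyl group on the core of compound 3 and compound 4, and whether it belongs to the four-membered ring or to the acetyl group. Also open, as far as these compounds go, is how a longer chain, or a carboxylic acid in place of the dimethylcarbamoyl part, would stand in this assay.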